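Replacing 3-methoxyphenyl in compound 3 with 4-methylphenyl

A few compounds are considered here, and "the series" means these few. Any claim that something is new, unique, unknown or untested is made for them only; others in the source may bear on it.

Compound 1 `Oc1c(C(Nc2ccccn2)c2ccccc2Cl)ccc2cccnc12`: 9400 nM
Compound 2 `Cc1ccc(C)c(C(Nc2ccccn2)c2ccc3cccnc3c2O)c1`: 13800 nM
Compound 3 `COc1cccc(C(Nc2ccccn2)c2ccc3cccnc3c2O)c1`: 11900 nM

All three compounds were tested in a functional assay on U-87MG ATCC cells for inhibition, with U-87 MG (Homo sapiens) as the target, read by MTT assay, with a stated time of 72 h; a lower number here means a stronger inhibitor, a higher number a weaker inhibitor. They share one core and differ only in the group on a saturated chain carbon bound to an aromatic carbon and a nitrogen on an aromatic ring. On these numbers, compound 3 at 11900 nM is not separated from either of the other two. The measured change is a 1.2-fold lower number from compound 2 to compound 3 (0.06 log units; within the scatter), and the other comparison is a 1.3-fold higher number from compound 1 to compound 3 (0.10 log units; within the scatter). The remaining exchange at this place is a 1.5-fold higher number from compound 1 to compound 2 (0.17 log units; within the scatter), so none of the three measured steps goes beyond the scatter.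

Compound 4 `Cc1ccc(C(Nc2ccccn2)c2ccc3cccnc3c2O)cc1` differs from compound 3 at that same place: 4-methylphenyl in place of 3-methoxyphenyl on a saturated chain carbon bound to an aromatic carbon and a nitrogen on an aromatic ring. Among the compounds with values here, no measured compound carries the 4-methylphenyl group, so the evidence is indirect and rests on the three exchanges above. With 2-chlorophenyl, 2,5-dimethylphenyl and 3-methoxyphenyl all giving steps within the scatter, no step beyond the scatter is expected in this assay, and no direction can be favoured. The estimated step is a 1.0-fold lower number from compound 3 to compound 4 (0.01 log units; within the scatter). The expected value for compound 4 is 11500 nM, with an estimated range of 7000 nM to 19000 nM.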

Compound 4, half-maximal inhibitory concentration: > 10000 nM
Compound 4 gave a limit, no number; the forecaster's own chance of this, stated with the estimate: 4%; the middle value does not contradict the limit.
By their numbers in this assay, from the lowest: compounds 1, 3 and 2 (each within the scatter of the next).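

In this assay compound 4, which carries 4-methylphenyl, gives > 10000 nM, and this is a limit of the assay and not a number. Within the data shown here, the only step that can be read is an at least 1.0-fold higher number from compound 1 to compound 4 (0.02 log units; that floor lies within the scatter), a floor that does not separate 4-methylphenyl from 2-chlorophenyl, while the other two new steps cannot be read. A fourth group on the saturated chain carbon, one that brings no hydrogen-bond acceptor in place of the one in 3-methoxyphenyl, therefore still gives no readable step beyond the scatter at this position, and the reading of this change ends at the edge of the assay: the limit of > 10000 nM in this assay, at which 1 of the 4 values shown sits.

Going by these compounds, all four compounds carry a substituted phenyl at this place, so it remains open whether a carboxylic acid, an amine or a longer alkyl chain there would move the number beyond the scatter. The rest of the shared core is identical in all four, which leaves open what an exchange elsewhere on it would do in this assay.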